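The source may hold more compounds than are shown below. What is called first, only, known or untested is meant among the compounds shown, and "the series" means these compounds.

Compound 1 `CC(=O)N1CCC(C)(C(=O)N2CC[C@](c3ccc(C(OCc4c(F)cccc4F)(C(F)(F)F)C(F)(F)F)cc3)(S(=O)(=O)c3ccc(F)cc3)C2)CC1`: 1%
Compound 2 `CC(=O)N1CCN(C(=O)N2CC[C@](c3ccc(C(OCc4c(F)cccc4F)(C(F)(F)F)C(F)(F)F)cc3)(S(=O)(=O)c3ccc(F)cc3)C2)CC1`: 5%
Compound 3 `O=C(O)[C@H]1CC[C@H](C(=O)N2CC[C@](c3ccc(C(OCc4ccccc4OC(F)(F)F)(C(F)(F)F)C(F)(F)F)cc3)(S(=O)(=O)c3ccc(F)cc3)C2)CC1`: 93%

In an ADME assay on microsomes from liver (Homo sapiens) for metabolic stability, with a stated time of 10 min (a higher number here means that more of the compound is left, a lower number that less of the compound is left), compound 3 stands highest of the three at 93%, beyond the scatter from both compound 1 and compound 2. Compound 4 `O=C(O)[C@H]1CC[C@H](C(=O)N2CC[C@](c3ccc(C(OCC4CCC4)(C(F)(F)F)C(F)(F)F)cc3)(S(=O)(=O)c3ccc(F)cc3)C2)CC1` differs from compound 3 by one change: cyclobutyl in place of 2-(trifluoromethoxy)phenyl on a saturated chain carbon bound to an oxygen on a saturated carbon. Going by the values given here, the only measured step, a number 4 percentage points higher from compound 1 to compound 2 (within the scatter), lies on a carbonyl carbon, not at this place, and it offers no direct guide to this change. Compound 3, at 93%, has little room to rise, and a high number with a moderate fall is expected. The expected step is a number 13 percentage points lower from compound 3 to compound 4 (beyond the scatter), an estimate with wide uncertainty. For compound 4 the estimate is 80%, with an expected range of 50% to 97%.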

Compound 4, percent of the compound remaining: 85%
Estimate against measurement, compound 4: 5 percentage points below; measured number inside the range.
By their numbers in this assay, from the lowest: compounds 1 and 2 (each within the scatter of the next); then compounds 4 and 3 (each within the scatter of the next).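

In this assay, cyclobutyl in place of 2-(trifluoromethoxy)phenyl gives a number 8 percentage points lower from compound 3 to compound 4 (within the scatter), so at this place the two groups cannot be told apart in this read-out. The earlier compounds shown here, compared only on a carbonyl carbon, did not show this. Nothing at hand explains the result. Compound 1 and compound 2 differ from compound 3 in more than one place, so the compounds shown do not assign the gap to any single group. On these data alone, whether an amine or a longer chain at this place would fare alike remains open.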